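Piperidin-1-yl in place of pyrrolidin-1-yl on the shared core

A few compounds are considered here, and "the series" means these few. Any claim that something is new, unique, unknown or untested is made for them only; others in the source may bear on it.

Measured in a functional assay on SK-MEL-28 cells (Homo sapiens) for inhibition, read by MTT assay, with a stated time of 72 h; a higher number here means a weaker inhibitor, a lower number a stronger inhibitor
- Compound 1 `C/C1=C\CC[C@@]2(C)O[C@@H]2[C@H]2OC(=O)[C@@H](CN3CCCCC3)[C@@H]2C[C@H]1O` gives 16000 nM
- Compound 2 `C/C1=C\CC[C@@]2(C)O[C@@H]2[C@H]2OC(=O)[C@@H](CN3CCCC3)[C@@H]2C[C@@H]1O` gives 23000 nM

Compound 2 (23000 nM) and compound 1 (16000 nM) lie within the usual scatter of each other, so these two values do not separate the compounds.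

Compound 3 `C/C1=C\CC[C@@]2(C)O[C@@H]2[C@H]2OC(=O)[C@@H](CN3CCCCC3)[C@@H]2C[C@@H]1O` is the next entry to compare with compound 2. The change is piperidin-1-yl in place of pyrrolidin-1-yl on a saturated chain carbon bound to a saturated ring carbon, with piperidin-1-yl in place of pyrrolidin-1-yl on a saturated chain carbon bound to a saturated ring carbon.

Among the measured compounds shown here, no measured pair isolates this change, so the data give no direct size for it. In this assay no step beyond the scatter is expected, and no direction is favoured. The estimated step is a 1.2-fold lower number from compound 2 to compound 3 (0.08 log units; within the scatter).

Compound 3 is expected at 19000 nM (estimated range 9000 nM to 40000 nM).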

Compound 3, half-maximal inhibitory concentration: 10000 nM
Estimate against measurement, compound 3: 1.9-fold (0.28 log units) above; low and high end bracket the measured number.
By their numbers in this assay, from the lowest: compounds 3, 1 and 2 (each within the scatter of the next, the first and the last beyond it).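

With the stereocentres held as in compound 2, the exchange of pyrrolidin-1-yl for piperidin-1-yl on a saturated chain carbon bound to a saturated ring carbon now has a direct size in this assay: a 2.3-fold lower number from compound 2 to compound 3 (0.36 log units; beyond the scatter), a modest step. Compounds 1 and 2 differ in both the amine and the drawn configuration, so they could not give this size. Configuration alone gives a 1.6-fold lower number from compound 1 to compound 3 (0.20 log units; within the scatter), so in this pair the stereocentre at a saturated ring carbon has no effect that can be told apart from the scatter, a reading that rests on one fact: the fact that compounds 1 and 3 differ only in the configuration as drawn

Pyrrolidin-1-yl is shown with only one configuration at that stereocentre, so whether the amine step holds in the other configuration stays open. Also open, going by these compounds, is how morpholin-4-yl or dimethylamino on the same saturated chain carbon would read in this assay.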